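Swapping the amine tail on the amide side chain

A few compounds are considered here, and "the series" means these few. Any claim that something is new, unique, unknown or untested is made for them only; others in the source may bear on it.

Measured so far:
compound 1, `Fc1ccc(-c2nc3cc(C(F)(F)F)ccc3[nH]2)cc1`, 60000 nM
compound 2, `CCN(CC)CC(=O)Nc1ccc(-c2nc3cc(C(F)(F)F)ccc3n2C)cc1`, 90000 nM

Both numbers come from an ADME assay on Vero cells (Chlorocebus sabaeus) for cytotoxicity; on this read-out lower numbers stand for higher toxicity in this test and higher numbers for lower toxicity in this test. Compound 2, with its amide side chain ending in diethylamino, shows the higher of the two numbers, yet the gap to compound 1 is within the usual scatter of this assay, so the two cannot be told apart here.

Compound 3, `CN1CCN(CC(=O)Nc2ccc(-c3nc4cc(C(F)(F)F)ccc4n3C)cc2)CC1`, is the next compound and has not yet been measured. It differs from compound 2 in one place: 4-methylpiperazin-1-yl in place of diethylamino on a saturated chain carbon bound to a carbonyl carbon. The rest of the molecule, including the shared core and the trifluoromethyl group, stays the same.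

Among the measured compounds shown here, no measured pair in this set shows what such a change does, so the expectation rests on the two values alone. The step from compound 2 to compound 3 is expected to stay within the scatter, that is no change at the digits printed from compound 2 to compound 3 (within the scatter). For compound 3 the estimate in this assay is 90000 nM, with a range from 40000 nM to 200000 nM.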

Compound 3, half-maximal cytotoxic concentration: > 100000 nM
Compound 3: only a limit was reported; the forecaster's own chance of this, stated with the estimate: 30%; middle value at least 1.1-fold (0.04 log units) from the limit.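

In this assay compound 3 gives > 100000 nM, which is a limit and not a number. Putting 4-methylpiperazin-1-yl in place of diethylamino on a saturated chain carbon bound to a carbonyl carbon gives an at least 1.1-fold higher number from compound 2 to compound 3 (0.04 log units; that floor lies within the scatter), so at this position the larger ring, with its second nitrogen, brings no sign of a lower number. How far the true value of compound 3 lies from that of compound 2 cannot be read from this step: the limit of > 100000 nM in this assay, at which 1 of the 3 values shown sits.

The compounds shown leave open whether morpholin-4-yl, a ring with oxygen in place of the methyl-bearing nitrogen, or a smaller dimethylamino group on the same carbon would read the same way. They also leave open whether a longer chain carrying the amine would give a lower number in this assay.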